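This account rests on a few compounds, and the source may have more. Where it says the series, first, only, none or still open, it means among the compounds named here.

Measured compounds:
- Compound 1, `O=[N+]([O-])c1ccc(Nc2nccc(-c3ccc(F)cc3)n2)cc1`: 7950 nM
- Compound 2, `COc1cccc(Nc2nccc(-c3ccc(Br)cc3)n2)c1`: 148000 nM
- Compound 3, `Clc1ccc(Nc2nccc(-c3ccc(Cl)cc3Cl)n2)c(Cl)c1`: 8080 nM

These three compounds share one core and were tested in a functional assay on HepG2 cells (Homo sapiens) for antiproliferative activity, read by MTT assay; on this read-out higher numbers stand for weaker inhibition and lower numbers for stronger inhibition. Compound 1 gives 7950 nM, the lowest of the three numbers. Compound 3, with 8080 nM, sits so close that the two cannot be told apart within the usual scatter of this assay, so neither can be called the stronger of the pair. Going by the values given here, compound 2, with 148000 nM, lies far from compound 1, well beyond the scatter, and is the only compound here whose number is clearly separated from the others.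

Compound 4, `O=[N+]([O-])c1ccc(Nc2nccc(-c3ccc(Br)cc3)n2)cc1`, has not yet been measured. It keeps the nitrophenyl side of compound 1 and changes only one atom on the other ring: bromo in place of fluoro on an aromatic carbon. Among the compounds with values here, no measured pair here differs by this single swap, so the size of the step is not known from the data. Compound 2 does carry a bromo group but also a different aniline, so its value alone cannot tell what the bromo contributes.

The expectation is that the step from fluoro to bromo in this assay is small, with compound 4 giving about 7000 nM, somewhere between 2500 nM and 20000 nM, which means an expected step of a 1.1-fold lower number from compound 1 to compound 4 (0.06 log units; within the scatter) that stays within the scatter of the measurement.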

Compound 4, half-maximal inhibitory concentration: 43000 nM
For compound 4 the middle estimate is 6.1-fold (0.79 log units) below the measured one; the measured number lies above the stated range.
By their numbers in this assay, from the lowest: compounds 1 and 3 (each within the scatter of the next); then compound 4; then compound 2.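

Going by these compounds alone, this is the first direct reading of this position in this assay. With the nitrophenyl side held fixed, bromo in place of fluoro gives a 5.4-fold higher number from compound 1 to compound 4 (0.73 log units; beyond the scatter), so changing one atom on the aromatic ring, para to a large group, is enough to move the number beyond the usual scatter, toward weaker inhibition. Neither group counts a ring, a hydrogen-bond donor, a hydrogen-bond acceptor or a net charge, and no measurement shown here explains the size of this step.

Within the data shown here, only this one pair carries the swap, so it remains open whether bromo in place of fluoro moves the number in the same direction and by a similar amount when the other side of the molecule carries a different group. Also open, from the compounds shown here alone, is how the number would respond at this position to groups of another kind, such as an amine, a nitrile or a carboxylic acid.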